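Methyl for Nitro on the Aryl Ring of the Dienone

A few compounds are considered here, and "the series" means these few. Any claim that something is new, unique, unknown or untested is made for them only; others in the source may bear on it.

Compound 1, `CC1=C(/C=C/C(=O)/C=C/c2ccccc2)C(C)(C)CCC1`, gives 20400 nM in a functional assay on IMR-32 cells (Homo sapiens) for cytotoxicity, read by sulforhodamine B assay, with a stated time of 48 h; on this read-out higher numbers stand for weaker inhibition and lower numbers for stronger inhibition.
Compound 2, `CC1=C(/C=C/C(=O)/C=C/c2ccc(F)cc2)C(C)(C)CCC1`, gives 7400 nM.
Compound 3, `CC1=C(/C=C/C(=O)/C=C/c2ccccc2[N+](=O)[O-])C(C)(C)CCC1`, gives 13500 nM.

Compound 3 stands second highest of the three numbers. Its distance from compound 1, the step of a 1.5-fold lower number from compound 1 to compound 3 (0.18 log units; within the scatter), lies within the scatter, and its number also lies within the scatter of the number of compound 2. Among the measured compounds shown here, the only step that reaches beyond the scatter is a 2.8-fold lower number from compound 1 to compound 2 (0.44 log units; beyond the scatter), and even that is modest.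

Compound 4, `CC1=C(/C=C/C(=O)/C=C/c2ccccc2C)C(C)(C)CCC1`, carries the change (methyl in place of nitro on an aromatic carbon). For the measured compounds named here, no measured compound bears a methyl on this ring, so the step has no direct parallel. What bears on it is that both measured swaps on the same aromatic ring, from compound 1 to compound 2 and from compound 1 to compound 3, moved the number only a little or not beyond the scatter. A change of similar small size, in either direction, is therefore expected in this assay. Compound 4 is estimated at 12000 nM, within a range from 5000 nM to 30000 nM, an expected step of a 1.1-fold lower number from compound 3 to compound 4 (0.05 log units; within the scatter).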

Compound 4, half-maximal inhibitory concentration: 63200 nM
Compound 4: the middle estimate sits 5.3-fold (0.72 log units) below what was measured; the measured number lies above the stated range.
By their numbers in this assay, from the lowest: compounds 2, 3 and 1 (each within the scatter of the next, the first and the last beyond it); then compound 4.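

The methyl group, on an aromatic carbon ortho to a large group, shows that this position does not tolerate every substituent equally in this assay: methyl in place of hydrogen gives a 3.1-fold higher number from compound 1 to compound 4 (0.49 log units; beyond the scatter), beyond the scatter, whereas nitro in place of hydrogen at the same carbon stayed within it. Methyl in place of nitro gives a 4.7-fold higher number from compound 3 to compound 4 (0.67 log units; beyond the scatter), so the two groups are clearly distinguished here, although neither is large in its step from hydrogen. Compound 4 is the weakest of the four, and the exchange of 2-methylphenyl for 4-fluorophenyl gives an 8.5-fold higher number from compound 2 to compound 4 (0.93 log units; beyond the scatter), the widest gap in the set.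

Nothing available here accounts for the difference between methyl and nitro. On these data alone, whether an amine, a methoxy group or a carboxylic acid at this carbon would follow methyl or nitro remains open, as does the effect of methyl elsewhere on the ring.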